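The compounds below may be only part of what the source reports. "The series", "measured", "known", "first", "only" and "open" are said of these compounds alone.

Measured compounds in an assay on H4 cells for inhibition of Fatty-acid amide hydrolase 1 (Homo sapiens); a lower number here means a stronger inhibitor, a higher number a weaker inhibitor:
compound 1, `CCOC(=O)CC(CCCCCn1c(C)nc(-c2ccccc2)c1-c1ccccc1)C(C)C`: > 100000 nM
compound 2, `Cc1nc(-c2ccccc2)c(-c2ccccc2)n1CCCCCC(NC(=O)Oc1ccccc1F)c1ccccc1`: 110 nM
compound 3, `CCOC(=O)CCCCCCn1c(C)nc(-c2ccc(F)cc2)c1-c1ccc(F)cc1`: 64 nM.

Compound 1's entry is a limit of the assay and not a number, (the limit of > 100000 nM in this assay, at which 1 of the 3 values shown sits). Among the two numbers given, compound 3 has the lowest; compound 2 sits close to it, within the scatter, so no order between the two can be drawn. Compound 4, `Cc1nc(-c2ccc(F)cc2)c(-c2ccc(F)cc2)n1CCCCCCNC(=O)Oc1c(F)cccc1F`, remains to be measured in this assay. Relative to compound 3 it carries ((2,6-difluorophenoxy)carbonyl)amino in place of ethoxycarbonyl on a saturated chain carbon, six bonds along the chain from an aromatic nitrogen. Among the compounds with values here, no pair of measured compounds isolates this change on its own; the only carbamate measured so far, compound 2, differs from compound 3 in more than one place and lands within its scatter. The expected step is a 2.6-fold lower number from compound 3 to compound 4 (0.41 log units; beyond the scatter), a modest move toward a lower number, with real doubt whether it clears the scatter. Compound 4 is estimated at 25 nM in this assay, with a range from 5 nM to 150 nM.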

Compound 4, half-maximal inhibitory concentration: 24 nM
Compound 4: the middle estimate sits 1.0-fold (0.02 log units) above what was measured, and the stated range covers the measured number.
By their numbers in this assay, from the lowest: compound 4; then compounds 3 and 2 (each within the scatter of the next). At a limit, above all of these: compound 1.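

In this assay, this place on the saturated chain, six bonds along the chain from an aromatic nitrogen, now has a comparison on an otherwise unchanged core: ((2,6-difluorophenoxy)carbonyl)amino in place of ethoxycarbonyl gives a 2.7-fold lower number from compound 3 to compound 4 (0.43 log units; beyond the scatter). The step is modest but beyond the scatter, so ethoxycarbonyl is not required at this place for a low number, and the change does not cost inhibition here. The entering group brings an aromatic ring and a hydrogen-bond donor together, and no measurement shown bears on which part of the change accounts for the step.

On these data alone, it remains open whether the two fluorines contribute, which an unsubstituted (phenoxycarbonyl)amino group on the same core would address. As far as these compounds go, how a carboxylic acid at this place, or a longer chain carrying the same carbamate, would compare also remains open.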